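Hydroxy to Chloro: From Compound 2 to Compound 3

The source may hold more compounds than are shown below. What is called first, only, known or untested is meant among the compounds shown, and "the series" means these compounds.

Compound 1, `COc1ccc(C(=O)/C=C/c2cc3ccccc3[nH]c2=O)cc1`, in a functional assay on SF-539 cells (Homo sapiens) for cytotoxicity, read by sulforhodamine B assay, with a stated time of 24 h; a lower number here means a stronger inhibitor of growth, a higher number a weaker inhibitor of growth: 7490 nM
Compound 2, `O=C(/C=C/c1cc2ccccc2[nH]c1=O)c1ccc(O)cc1`, in this assay: 8640 nM

Compound 2 has the higher of the two numbers, though its step from compound 1, a 1.2-fold higher number from compound 1 to compound 2 (0.06 log units; within the scatter), lies within the scatter. Compound 3, `O=C(/C=C/c1cc2ccccc2[nH]c1=O)c1ccc(Cl)cc1`, is not yet measured; it differs from compound 2 by chloro in place of hydroxy on an aromatic carbon, para to a large group. For the measured compounds named here, the only measured step touches the same position and was within the scatter, so no shift beyond the scatter is expected here either. Compound 3 is expected to give 6000 nM in this assay, between 2500 nM and 14000 nM. The expected step is a 1.4-fold lower number from compound 2 to compound 3 (0.16 log units; within the scatter).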

Compound 3, concentration for total growth inhibition: 8020 nM
Beside the measured number, compound 3's estimate is 1.3-fold (0.13 log units) below it; measured number inside the range.
By their numbers in this assay, from the lowest: compounds 1, 3 and 2 (each within the scatter of the next).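

In this assay, only oxygen-linked groups had stood para to a large group until now, and chloro, with 0 hydrogen-bond donors and 0 hydrogen-bond acceptors, reads alike with hydroxy (a 1.1-fold lower number from compound 2 to compound 3 (0.03 log units; within the scatter)) and with methoxy (a 1.1-fold higher number from compound 1 to compound 3 (0.03 log units; within the scatter)). All three groups at this position therefore lie within the scatter of one another. Nothing available bears on the reason for this result. The compounds shown leave open whether an amine, a carboxylic acid or a longer chain at this position would move the number beyond the scatter.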